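The source may hold more compounds than are shown below. What is called first, only, known or untested is meant among the compounds shown, and "the series" means these compounds.

Measured in an ADME assay on HepG2 cells (Homo sapiens) for cytotoxicity, with a stated time of 72 h; a higher number here means that more compound is needed for the effect, a lower number that less compound is needed:
- Compound 1 `CSc1ccc(NC(=O)Nc2cc(C)nc3ccccc23)cc1`: 16000 nM
- Compound 2 `CCc1ccc(NC(=O)Nc2cc(C)nc3ccccc23)cc1`: 17000 nM

In this assay compound 2 gives 17000 nM, which lies within the scatter of compound 1. Compound 3 `CC(=O)c1ccc(NC(=O)Nc2cc(C)nc3ccccc23)cc1` has not been measured. It carries acetyl in place of ethyl on an aromatic carbon, para to a large group: acetyl in place of ethyl on an aromatic carbon. Among the compounds with values here, only one measured step bears on this change, since it swaps a group at that same place: a 1.1-fold higher number from compound 1 to compound 2 (0.03 log units; within the scatter). That single step stayed within the scatter, so the expected change here is no step beyond the scatter, namely a 1.1-fold lower number from compound 2 to compound 3 (0.03 log units; within the scatter). Compound 3 is estimated at 16000 nM, with an expected range of 8000 nM to 32000 nM.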

Compound 3, half-maximal effective concentration: 19000 nM
Beside the measured number, compound 3's estimate is 1.2-fold (0.07 log units) below it, and the stated range covers the measured number.
By their numbers in this assay, from the lowest: compounds 1, 2 and 3 (each within the scatter of the next).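

In this assay the acetyl group on this aromatic carbon, para to a large group, gives a 1.1-fold higher number from compound 2 to compound 3 (0.05 log units; within the scatter) and a 1.2-fold higher number from compound 1 to compound 3 (0.07 log units; within the scatter) so the three groups seen at this place read alike. Acetyl brings a hydrogen-bond acceptor and a double bond that ethyl lacks, and even this swap leaves the number within the scatter. No evidence here says why the numbers stay together. Still open, going by these compounds, is whether an amine, a carboxylic acid or a longer chain at this place would move the number beyond the scatter.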